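A few compounds are considered here, and "the series" means these few. Any claim that something is new, unique, unknown or untested is made for them only; others in the source may bear on it.

In a functional assay on CNE-2 cells (Homo sapiens) for cytotoxicity, read by MTT assay, with a stated time of 72 h (on this read-out lower numbers stand for stronger inhibition and higher numbers for weaker inhibition), compound 3 `COc1cc2ncnc(NNC(=S)NC(=O)c3ccc(F)cc3)c2cc1OC` gives 16100 nM, the largest of the three numbers measured, though its gaps to the other two are both small. Compared with compound 1 `COc1cc2ncnc(NNC(=S)NC(=O)c3ccccc3F)c2cc1OC`, which gives 12700 nM, the change is a 1.3-fold higher number from compound 1 to compound 3 (0.10 log units; within the scatter); compared with compound 2 `COc1cc2ncnc(NNC(=S)NC(=O)c3ccccc3OC)c2cc1OC`, which gives 8410 nM, it is a 1.9-fold higher number from compound 2 to compound 3 (0.28 log units; within the scatter). Between the first two compounds the step is a 1.5-fold lower number from compound 1 to compound 2 (0.18 log units; within the scatter). Compound 4 `COc1cc2ncnc(NNC(=S)NC(=O)c3ccc(C(F)(F)F)cc3)c2cc1OC` differs from compound 3 in a single place: trifluoromethyl in place of fluoro on an aromatic carbon. For the measured compounds named here, no measured pair shows a trifluoromethyl entering for a fluoro, so nothing speaks to this swap directly. Going by the values given here, the only steps that touch groups on the same ring, those among compound 1, compound 2 and compound 3, all stayed within the usual scatter, which gives no reason to expect a larger move here. For compound 4 the expected step is therefore a 1.2-fold lower number from compound 3 to compound 4 (0.06 log units; within the scatter), with no preferred direction. Compound 4 is estimated at 14000 nM, with a range from 5000 nM to 40000 nM.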

Compound 4, half-maximal inhibitory concentration: 16500 nM
Beside the measured number, compound 4's estimate is 1.2-fold (0.07 log units) below it, within the range that was stated.
By their numbers in this assay, from the lowest: compounds 2, 1, 3 and 4 (each within the scatter of the next).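

In this assay, the step of a 1.0-fold higher number from compound 3 to compound 4 (0.01 log units; within the scatter) shows that this carbon, para to a large group, can carry trifluoromethyl as well as fluoro with no change beyond the scatter. For the compounds shown here, until now, the only changes on this ring had swapped one small substituent for another, so this is the first sign that a group with more heavy atoms can sit here without separating the compounds. The wider comparisons agree, since neither a 2.0-fold higher number from compound 2 to compound 4 (0.29 log units; within the scatter) nor a 1.3-fold higher number from compound 1 to compound 4 (0.11 log units; within the scatter) goes beyond the scatter, so no step shown among these four compounds separates any of them.

Going by these compounds, whether an amine or a carboxylic acid on this same carbon would move the number beyond the scatter remains open. No measurement shown offers a reason for this result.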